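Propyl to cyclohexyl on the amine nitrogen: expected read-out

The compounds below may be only part of what the source reports. "The series", "measured", "known", "first", "only" and "open" are said of these compounds alone.

Measured so far:
compound 1 `CCCNC(=C\C(=O)/C=C/c1ccc(O)c(OC)c1)/C=C/c1ccc(O)c(OC)c1` gives 88%
compound 2 `CC(C)CNC(=C\C(=O)/C=C/c1ccc(O)cc1)/C=C/c1ccc(O)cc1` gives 82%
compound 3 `COc1cc(/C=C/C(=O)/C=C(/C=C/c2ccc(OC(C)=O)c(OC)c2)NCC(C)C)ccc1OC(C)=O` gives 77%

All three numbers come from a functional assay on Caco-2 cells (Homo sapiens), read by fluorescence, tested at 10 uM; a lower number here means a stronger effect, a higher number a weaker effect of the compound at the concentration tested. Compound 1 stands highest of the three numbers. Compound 2 lies nearest to it, and the gap between the two is within the usual scatter of this assay, so no order between compound 1 and compound 2 can be read from these numbers. Compound 3 lies furthest, with a number beyond the scatter below that of compound 1. Within the data shown here, no pair among the measured compounds differs in only one place, so no single structural change has yet been followed with a measured step.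

Compound 4 `COc1cc(/C=C/C(=O)/C=C(/C=C/c2ccc(O)c(OC)c2)NC2CCCCC2)ccc1O` is not yet measured. It differs from compound 1 in one place: cyclohexyl in place of propyl on an amine nitrogen. The other parts of compound 1 are kept. Among the measured compounds shown here, nothing among the measured compounds speaks to this change, and no step is available to set its size. Compound 4 is therefore expected to give a number close to that of compound 1, and the step of a number 3 percentage points lower from compound 1 to compound 4 (within the scatter) is estimated as no change beyond the scatter in this assay. For compound 4 the estimate is 85%, with a range from 70% to 96% expected.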

Compound 4, a percentage reported as activity, at one concentration (the size of the read-out at that concentration, not a potency): 63%
Compound 4: the middle estimate sits 22 percentage points above what was measured; measured number outside the range, below it.
By their numbers in this assay, from the lowest: compound 4; then compounds 3, 2 and 1 (each within the scatter of the next, the first and the last beyond it).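

In this assay the amine nitrogen now shows itself to be a position that responds: cyclohexyl in place of propyl gives a number 25 percentage points lower from compound 1 to compound 4 (beyond the scatter) with the rest of the core of compound 1 kept. Among these compounds, this is the first single change followed with a measured step, and it runs towards a stronger effect at the concentration tested, a finding that rests on this one pair alone. No measured data bearing on the origin of this step are available.

Cyclohexyl differs from propyl both in carbon count and in carrying a ring, so this pair cannot separate the two, and an open hexyl chain or a cyclopropyl group on the same nitrogen would be needed to tell them apart. Also open, as far as these compounds go, is whether a ring of another kind on this nitrogen, such as phenyl or a piperidine, would hold the step, and whether cyclohexyl has a similar effect on the cores of the other compounds.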